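Trading chloro for trifluoromethyl in a growth inhibition test

The compounds below may be only part of what the source reports. "The series", "measured", "known", "first", "only" and "open" are said of these compounds alone.

compound 1 `O=C(CCCCC1CCSS1)Nc1cccc(C(F)(F)F)c1` gives 10.9%
compound 2 `O=C(CCCCC(S)CCS)Nc1ccccc1` gives 8.62%
compound 3 `O=C(CCCCC(S)CCS)Nc1cccc(Cl)c1` gives "not active" (no number reported)

In a functional assay on KB cells (Homo sapiens) for inhibition, read by MTT assay, with a stated time of 24 h, tested at 10 ug/mL (a lower number here means less inhibition of growth, a higher number more inhibition of growth at the concentration tested), compound 3 is reported as "not active" (no number reported) and has no single number to compare against. Still without a result is compound 4 `O=C(CCCCC(S)CCS)Nc1cccc(C(F)(F)F)c1` as the next structure to examine. The change trifluoromethyl in place of chloro on an aromatic carbon puts trifluoromethyl in place of chloro on an aromatic carbon. Going by the values given here, no measured pair shows what this swap does on its own. Compound 1 also carries trifluoromethyl, differs elsewhere, and gives 10.9% as its result, while compound 2 gives 8.62% as its result. On that basis, a step in this assay no larger than the usual scatter is expected, with neither direction favoured. Compound 4 is expected near 9% with a likely range of 0% to 22% if a number is reported at all.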

Compound 4, percent growth inhibition at one concentration: 1.97%
For compound 4 the middle estimate is 7 percentage points above the measured one; the range from low to high includes it.
By their numbers in this assay, from the lowest: compounds 4, 2 and 1 (each within the scatter of the next).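

In this assay trifluoromethyl in place of hydrogen on the aromatic carbon gives a number 6.7 percentage points lower from compound 2 to compound 4 (within the scatter) and the open chain in place of the five-membered ring gives a number 8.9 percentage points lower from compound 1 to compound 4 (within the scatter) so neither change stands clear of the usual scatter here. The swap of chloro for trifluoromethyl itself still cannot be read, since compound 3 has no number. Nothing measured here accounts for these results.

Open, as far as these compounds go, is whether an amine or a carboxylic acid on this aromatic carbon would give a number clearly apart from these. Open too, from the compounds shown here alone, is what a longer chain in place of the present one would do.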